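The source may hold more compounds than are shown below. What is called first, only, known or untested is meant among the compounds shown, and "the series" means these compounds.

Working notes on the aminothiazole series. Within the data shown here, compound 1 `Cc1nc(N)sc1CCCN/C(N)=N/C(=O)NCc1ccco1` gives the lower of the two numbers so far: in an assay on membranes from Sf9 cells for displacement of a labelled ligand from histamine H2 receptor (Homo sapiens), read by scintillation counting, with a stated time of 60 min (a higher number here means a weaker inhibitor, a lower number a stronger inhibitor), compound 1 gives 10.5 nM. Compound 2 `Cc1nc(N)sc1CCCN/C(N)=N/C(=O)NC(C)c1ccc(OC(F)(F)F)cc1` carries a branched benzylic group on the same nitrogen and in this assay compound 2 gives 126 nM, a gap to compound 1 that lies beyond the usual scatter. Among the measured compounds shown here, no single-point step between measured compounds is available, so the next change is judged from compound 1 alone. Compound 3 `Cc1nc(N)sc1CCCN/C(N)=N/C(=O)NC1CCCCC1` differs from compound 1 by cyclohexyl in place of (furan-2-yl)methyl on an amide-type nitrogen. For the measured compounds named here, no measured pair shows what this exchange does, and the only other variation at this nitrogen, in compound 2, points toward weaker binding with a larger group. The step from compound 1 to compound 3 is therefore expected to be modest, a 2.4-fold higher number from compound 1 to compound 3 (0.38 log units; beyond the scatter), toward a higher number but possibly within scatter. For compound 3 the estimate in this assay is 25 nM, with a range from 8 nM to 80 nM.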

Compound 3, inhibition constant: 170 nM
The estimate for compound 3 lay 6.8-fold (0.83 log units) below the measured number; the whole stated range lies below it.
By their numbers in this assay, from the lowest: compound 1; then compounds 2 and 3 (each within the scatter of the next).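

In this assay, cyclohexyl in place of (furan-2-yl)methyl on the amide-type nitrogen is a large step, a 16-fold higher number from compound 1 to compound 3 (1.21 log units; beyond the scatter) even though the entering and leaving groups have the same count of heavy atoms, so that count alone does not set the number at this position. The step also shows that a larger number here does not require the branched benzylic group: compound 2 at 126 nM and compound 3 at 170 nM lie within the scatter of each other, and compound 1 stands apart from both.

Still open, on these data alone, is whether the furan oxygen, the aromatic ring or the methylene link carries the difference; a benzyl or a (tetrahydrofuran-2-yl)methyl group at this nitrogen would bear on that. No measurement at hand accounts for the size of this step.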